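A few compounds are considered here, and "the series" means these few. Any claim that something is new, unique, unknown or untested is made for them only; others in the source may bear on it.

Three analogues sharing one core have been run in a functional assay on MGC-803 cells (Homo sapiens) for inhibition, read by sulforhodamine B assay; a lower number here means a stronger inhibitor, a higher number a weaker inhibitor. Compound 1 `O=C1C=C(Nc2ccc(I)cc2)C(=O)c2c1nc1n2[C@H]2OC[C@@H](O)[C@H]2OC1` gives 1400 nM in this assay. Among the measured compounds shown here, compound 2 `CCc1ccc(NC2=CC(=O)c3nc4n(c3C2=O)[C@H]2OC[C@@H](O)[C@H]2OC4)cc1` gives 1290 nM in this assay, and the step of a 1.1-fold lower number from compound 1 to compound 2 (0.04 log units; within the scatter) is the only single-point change measured so far. Compound 3 `COc1ccccc1NC1=CC(=O)c2c(nc3n2[C@H]2OC[C@@H](O)[C@H]2OC3)C1=O` gives 1670 nM in this assay, the highest of the three numbers, although its gaps to compound 1 and to compound 2 both sit within the scatter, so the three compounds cannot be ordered against each other.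

Compound 4 `O=C1C(Nc2cccc(F)c2)=CC(=O)c2c1nc1n2[C@H]2OC[C@@H](O)[C@H]2OC1` has not yet been measured. It differs from compound 3 by 3-fluorophenyl in place of 2-methoxyphenyl on an amine nitrogen. For the measured compounds named here, the only step at hand, a 1.1-fold lower number from compound 1 to compound 2 (0.04 log units; within the scatter), concerns a substituent on an aromatic carbon rather than the exchange of 2-methoxyphenyl for 3-fluorophenyl on the amine nitrogen, and it stayed within the scatter. No change in the series has yet moved the number beyond the scatter, so none is expected here either. Compound 4 is therefore expected to give about 1500 nM in this assay, between 700 nM and 3500 nM. The expected step is a 1.1-fold lower number from compound 3 to compound 4 (0.05 log units; within the scatter).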

Compound 4, half-maximal inhibitory concentration: 1470 nM
Compound 4: middle estimate off by 1.0-fold (0.01 log units), on the high side; the range from low to high includes it.
By their numbers in this assay, from the lowest: compounds 2, 1, 4 and 3 (each within the scatter of the next).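

The exchange of 2-methoxyphenyl for 3-fluorophenyl on the amine nitrogen replaces the whole substituted phenyl group, not just one substituent, and gives a 1.1-fold lower number from compound 3 to compound 4 (0.06 log units; within the scatter) in this assay. The leaving group carries one hydrogen-bond acceptor and the entering group none, yet the step stays within the scatter, so this acceptor count makes no readable difference between these two compounds. No measurement is at hand that could explain this result.

On these data alone, all four compounds carry a substituted phenyl on the amine nitrogen, so it remains open whether any group at this position can move the number beyond the scatter. A longer alkyl chain or a morpholine in place of the phenyl, or a carboxylic acid on the phenyl, would test this.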